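The compounds below may be only part of what the source reports. "The series", "measured", "known", "first", "only" and "open" are said of these compounds alone.

Measured so far in an ADME assay on NIH3T3 cells (Mus musculus) for cytotoxicity, with a stated time of 72 h; a higher number here means a weaker inhibitor, a lower number a stronger inhibitor:
compound 1 `OC[C@H]1O[C@@H](n2cnc3c(NCc4ccc(F)cc4)ncnc32)[C@H](O)[C@@H]1O` — 44300 nM
compound 2 `Cc1cccc(CNc2ncnc3c2ncn3[C@@H]2O[C@H](CO)[C@@H](O)[C@H]2O)c1` — > 166000 nM

In this assay, among the measured compounds shown here, compound 1 gives 44300 nM, the only numerical value among the two results. Compound 2 gives only a limit of this assay, > 166000 nM, which marks the point past which no number is reported (the limit of > 166000 nM in this assay, at which 1 of the 2 values shown sits). For the measured compounds named here, the one measured step, an at least 3.7-fold higher number from compound 1 to compound 2 (0.57 log units; beyond the scatter), points toward a weaker inhibitor.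

Compound 3 `OC[C@H]1O[C@@H](n2cnc3c(NCc4ccc(F)cc4F)ncnc32)[C@H](O)[C@@H]1O` differs from compound 1 by fluoro in place of hydrogen on an aromatic carbon. Going by the values given here, no measured step adds a fluoro to an aromatic carbon; the only step replaces one aryl group with another, so it offers little direct guidance for this change. The expected step is therefore within the usual scatter, a 1.1-fold higher number from compound 1 to compound 3 (0.05 log units; within the scatter). Compound 3 is estimated at 50000 nM, with a range from 20000 nM to 130000 nM.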

Compound 3, half-maximal inhibitory concentration: > 166000 nM
Compound 3: only a limit was reported; the forecaster's own chance of this, stated with the estimate: 20%; middle value at least 3.3-fold (0.52 log units) from the limit.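

In this assay compound 3 gives only a limit, > 166000 nM, not a number. The change from 4-fluorobenzyl to 2,4-difluorobenzyl, the only difference between the two compounds, gives an at least 3.7-fold higher number from compound 1 to compound 3 (0.57 log units; beyond the scatter), so one added fluoro at this place, ortho to a large group and meta to the fluoro group already there, is enough to move the result beyond the scatter toward a weaker inhibitor. The step between compound 2 and compound 3 cannot be read, and compound 1 remains the only one with a number: the limit of > 166000 nM in this assay, at which 2 of the 3 values shown sit.

The compounds shown leave open whether this shift is specific to fluoro or would also follow from a chloro or a methoxy group at the same place. They also leave open how an unsubstituted benzyl group would compare with compound 1.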